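Moving the methyl on the triazole of compound 2

A few compounds are considered here, and "the series" means these few. Any claim that something is new, unique, unknown or untested is made for them only; others in the source may bear on it.

For the measured compounds named here, compound 2 `Cn1ncnc1-c1cc(Oc2ccc(NC(=O)N/N=C/c3ccccc3)cc2F)ccn1` gives the higher of the two numbers so far in a functional assay on HT-29 cells (Homo sapiens) for cytotoxicity, read by MTT assay, with a stated time of 72 h; a lower number here means a stronger inhibitor, a higher number a weaker inhibitor: compound 2 gives 30200 nM, while compound 1 `CN(C)CCn1cnnc1-c1cc(Oc2ccc(NC(=O)N/N=C/c3ccccc3)cc2F)ccn1` gives 1120 nM. Going by the values given here, the one measured step, a 27-fold higher number from compound 1 to compound 2 (1.43 log units; beyond the scatter), is large. Compound 3 `Cn1cnnc1-c1cc(Oc2ccc(NC(=O)N/N=C/c3ccccc3)cc2F)ccn1` differs from compound 2 by 4-methyl-4H-1,2,4-triazol-3-yl in place of 1-methyl-1H-1,2,4-triazol-5-yl on an aromatic carbon. The incoming ring carries its methyl the way the ring of compound 1 carries its larger chain, so that step bears on this change, though only partly, as the chain itself is not restored. Compound 3 is therefore expected to give a lower number, a 5.0-fold lower number from compound 2 to compound 3 (0.70 log units; beyond the scatter), with an estimate of 6000 nM ranging from 1500 nM to 24000 nM.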

Compound 3, half-maximal inhibitory concentration: 8790 nM
The estimate for compound 3 lay 1.5-fold (0.17 log units) below the measured number; the range from low to high includes it.
By their numbers in this assay, from the lowest: compound 1; then compound 3; then compound 2.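

In this assay the ring change alone, with the same atoms joined differently, gives a 3.4-fold lower number from compound 2 to compound 3 (0.54 log units; beyond the scatter) and so shows that the place of the methyl on the triazole counts by itself. Losing the (dimethylamino)methyl part of the chain gives a 7.8-fold higher number from compound 1 to compound 3 (0.89 log units; beyond the scatter) and so accounts for the rest of the gap. No measurement here explains either step.

Still open, going by these compounds, is whether the dimethylamino group itself matters, or whether a plain propyl chain or a chain ending in a carboxylic acid would serve equally well.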